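A few compounds are considered here, and "the series" means these few. Any claim that something is new, unique, unknown or untested is made for them only; others in the source may bear on it.

Compound 1 `O=C(CCCCC(S)CCS)NO` gives 17.7%
Compound 2 `O=C(CCCCC(S)CCS)Nc1ccccc1` gives 8.37%
Compound 3 `O=C(CCCCC(S)CCS)Nc1ccccc1Cl` gives 18.2%

All three values come from a functional assay on NCI-H460 cells (Homo sapiens) for inhibition, read by MTT assay, with a stated time of 24 h, tested at 10 ug/mL; a higher number here means more inhibition of growth at the concentration tested, a lower number less inhibition of growth. Compound 2 stands within the scatter of both of the other compounds, as the two steps that touch it show: a number 9.3 percentage points lower from compound 1 to compound 2 (within the scatter) and a number 9.8 percentage points higher from compound 2 to compound 3 (within the scatter). Compound 4 `O=C(CCCCC(S)CCS)Nc1ccc(Cl)cc1` has not yet been measured. It has chloro in place of hydrogen on an aromatic carbon of the six-membered ring, para to a large group: chloro in place of hydrogen on an aromatic carbon. The first of the two steps involves a change at the amide-type nitrogen, so it says little about this replacement. Among the measured compounds shown here, the second involves the same replacement on a different aromatic carbon, and it is the only measured guide. Since that step stays within the scatter, no change beyond the scatter is expected in this assay, though a slight rise in the same direction would fit. The expected step is a number 4.6 percentage points higher from compound 2 to compound 4 (within the scatter). For compound 4 the estimated value is 13%, with an expected range from 4% to 26%.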

Compound 4, percent growth inhibition at one concentration: 22%
The estimate for compound 4 lay 9 percentage points below the measured number, within the range that was stated.
By their numbers in this assay, from the lowest: compounds 2, 1, 3 and 4 (each within the scatter of the next, the first and the last beyond it).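

In this assay, among the compounds shown here, chloro in place of hydrogen on an aromatic carbon, para to a large group, gives a number 13.6 percentage points higher from compound 2 to compound 4 (beyond the scatter) and is thus the first instance of this replacement to pass beyond the scatter, if only modestly. The same replacement on a different aromatic carbon gave a number 9.8 percentage points higher from compound 2 to compound 3 (within the scatter) and stayed within it, yet compound 3 at 18.2% and compound 4 at 22% lie within the scatter of each other, so the two chloro placements cannot be ranked. No measurement offers an explanation for the new step.

The compounds shown leave open whether fluoro, methyl or methoxy on this same aromatic carbon would give a step of similar size. They also leave open whether the chloro replacement would have the same effect with a longer chain in the core of compound 2.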